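A pentyl chain on selenium: from compound 3 to compound 4

This account rests on a few compounds, and the source may have more. Where it says the series, first, only, none or still open, it means among the compounds named here.

Of the compounds shown here, three have been tested in an ADME assay on 184B5 cells (Homo sapiens) for cytotoxicity, read by MTT assay, with a stated time of 72 h; a lower number here means a stronger inhibitor of growth, a higher number a weaker inhibitor of growth. Compound 1 `CCCCC[Se]c1nc([Se]CCCCC)c2ccccc2n1` reaches only the limit of the assay, > 100000 nM. Compound 2 `CCCCC[Se]c1nc(NCc2ccccc2)c2ccccc2n1` likewise returns a limit, > 100000 nM. The step that the two limits leave unreadable from compound 1 to compound 2 therefore cannot be read, since both of its ends sit at the limit of > 100000 nM in this assay, at which 2 of the 3 values shown sit. Among the compounds with values here, compound 3 `Nc1nc([SeH])nc2ccccc12` is the only member with an actual number in this assay, 36700 nM, and so it stands as the sole reference point among the three.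

Compound 4 `CCCCC[Se]c1nc(N)c2ccccc2n1` differs from compound 3 by pentyl in place of hydrogen on a selenium. Within the data shown here, no measured step shares this change, and the single step available, from compound 1 to compound 2, concerns a different position and is unreadable in any case. What the data do offer is that compound 1 and compound 2, the two members that carry a pentyl chain on a selenium, both end at the limit, whereas compound 3, with hydrogen on that selenium, does not. On that slender basis a weakening is expected for compound 4, estimated as the step of a 2.5-fold higher number from compound 3 to compound 4 (0.39 log units; beyond the scatter). Compound 4 is therefore expected at about 90000 nM, within 30000 nM to 250000 nM, with a real chance that only a limit is reported.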

Compound 4, concentration for total growth inhibition: 43600 nM
Compound 4: middle estimate off by 2.1-fold (0.31 log units), on the high side; measured number inside the range.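

In this assay, pentyl in place of hydrogen on a selenium gives a 1.2-fold higher number from compound 3 to compound 4 (0.07 log units; within the scatter), so compound 4 goes against the earlier impression that a pentyl chain on selenium travels with the limit of the assay. The separation from the limit instead appears at the other place on the shared core: hydrogen in place of benzyl on a nitrogen on an aromatic ring gives an at least 2.2-fold lower number from compound 2 to compound 4 (0.36 log units; beyond the scatter), and one nitrogen atom in place of a group of 6 heavy atoms on an aromatic carbon gives an at least 2.2-fold lower number from compound 1 to compound 4 (0.36 log units; beyond the scatter). Both of these steps are bounded on one side only, and their full size stays unknown, as compound 1 and compound 2 each return a limit and not a number: the limit of > 100000 nM in this assay, at which 2 of the 4 values shown sit.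

The compounds shown leave open whether a shorter methyl chain or a longer octyl chain on selenium would also stay within the scatter of compound 3. They also do not tell whether a smaller group on the nitrogen, such as methyl, would keep compound 4's reading or move towards the limit seen with benzyl.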